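Adding a Second Chlorine to an Aryl Ether Side Chain

A few compounds are considered here, and "the series" means these few. Any claim that something is new, unique, unknown or untested is made for them only; others in the source may bear on it.

Within the data shown here, compound 2, `NC1=NC2(CCSCC2)N(OCCCOc2cccc(Cl)c2)C(N)=N1`, is the only member of this small set with a reported number: in an assay on isolated protein for inhibition of Dihydrofolate reductase (Homo sapiens), read by spectrophotometry, using NADPH, with stated times of 5 s and 6 min, tested at 50 uM (on this read-out higher numbers stand for a stronger effect at the one concentration tested and lower numbers for a weaker effect), compound 2 gives 88.8%. Compound 1, `NC1=NC2(CCOCC2)N(OCCCOc2ccccc2)C(N)=N1`, has no result in this assay ("not determined" (no result reported)), and compound 3, `NC1=NC2(CCOCC2)N(OCCCOc2ccc(Cl)cc2)C(N)=N1`, likewise none ("not determined" (no result reported)). Compound 4, `NC1=NC2(CCSCC2)N(OCCCOc2cccc(Cl)c2Cl)C(N)=N1`, is the compound still to be measured. It differs from compound 2 by chloro in place of hydrogen on an aromatic carbon. Among the measured compounds shown here, with a single anchor point and no measured step to lean on, the change from compound 2 to compound 4 is expected to stay within the usual scatter, perhaps edging upward, an estimated step of a number 1.2 percentage points higher from compound 2 to compound 4 (within the scatter). Compound 4 is therefore expected to reach about 90%, within a range from 78% to 97%.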

Compound 4, a percentage reported as inhibition, at one concentration (the size of the read-out at that concentration, not a potency): 89.8%
Compound 4: middle estimate off by 0.2 percentage points, on the high side, and the stated range covers the measured number.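

In this assay, placing chloro on an aromatic carbon ortho to a chloro group, which turns 3-chlorophenyl into 2,3-dichlorophenyl, gives a number 1 percentage points higher from compound 2 to compound 4 (within the scatter). This position therefore accepts a second chloro with no readable change in the read-out at the one concentration tested, although such a reading is not a potency and could hide a difference in potency. Nothing shown here offers an explanation for this result. As far as these compounds go, whether an amine or a carboxylic acid on this same aromatic carbon would give a similar reading remains open. So does the outcome of a longer chain between the core and the aromatic ring.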